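Swapping Bromo for Hydroxy in a Cytotoxic Series

The compounds below may be only part of what the source reports. "The series", "measured", "known", "first", "only" and "open" are said of these compounds alone.

Compound 1 `C=C1[C@@H](OC(C)=O)C[C@@H]2[C@](C)(COC=O)[C@H](OC(C)=O)CC[C@@]2(C)[C@@H]1C[C@@H](Nc1ccc(Br)cc1)C1=CCOC1=O` gives 11400 nM in a functional assay on MCF7 cells (Homo sapiens) for cytotoxicity, read by sulforhodamine B assay (a lower number here means a stronger inhibitor, a higher number a weaker inhibitor), the highest of the two numbers seen so far. Among the measured compounds shown here, compound 2 `C=C1[C@@H](OC(C)=O)C[C@@H]2[C@](C)(CO[Si](C)(C)C(C)(C)C)[C@H](OC(C)=O)CC[C@@]2(C)[C@@H]1C[C@@H](Nc1ccc(OC)cc1)C1=CCOC1=O` sits lower: in this assay compound 2 gives 4280 nM, yet it differs from compound 1 in two places, so no single step links them. Compound 3 `C=C1[C@@H](OC(C)=O)C[C@@H]2[C@](C)(COC=O)[C@H](OC(C)=O)CC[C@@]2(C)[C@@H]1C[C@@H](Nc1ccc(O)cc1)C1=CCOC1=O` has not yet been measured; it differs from compound 1 by hydroxy in place of bromo on an aromatic carbon. For the measured compounds named here, no measured step of this kind exists here, so the expected step is a 1.4-fold lower number from compound 1 to compound 3 (0.15 log units; within the scatter), a small move toward a lower number that may not exceed the scatter. Compound 3 is therefore estimated at 8000 nM, within 3000 nM to 25000 nM.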

Compound 3, half-maximal inhibitory concentration: 18100 nM
Estimate against measurement, compound 3: 2.3-fold (0.35 log units) below, and the stated range covers the measured number.
By their numbers in this assay, from the lowest: compound 2; then compounds 1 and 3 (each within the scatter of the next).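

In this assay, this position now has its first single-place step, which reads a 1.6-fold higher number from compound 1 to compound 3 (0.20 log units; within the scatter). On an aromatic carbon para to a large group, the exchange brings in one hydrogen-bond donor and one hydrogen-bond acceptor, yet the two compounds cannot be told apart by this read-out. Nothing at hand speaks to the reason for this. Still open, going by these compounds, is whether an amine or a carboxylic acid at this place on the core of compound 1 would shift the number beyond the scatter.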